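Methyl for methoxy at the shared core, one compound still open

The source may hold more compounds than are shown below. What is called first, only, known or untested is meant among the compounds shown, and "the series" means these compounds.

In a functional assay on the whole organism for inhibition, with Chenopodium ficifolium as the target, with a stated time of 72 h, tested at 10 mg/L (a higher number here means more inhibition of growth at the concentration tested, a lower number less inhibition of growth), the measured compounds give:
compound 1 `COc1cc(SC)nc(NC(=S)NC(=O)c2c(-c3ccc(Cl)cc3Cl)noc2C)n1`: -8.31%
compound 2 `CSc1cc(C)nc(NC(=S)NC(=O)c2c(-c3ccc(Cl)cc3Cl)noc2C)n1`: 32.8%
compound 3 `COc1cc(OC)nc(NC(=S)NC(=O)c2c(-c3ccc(Cl)cc3Cl)noc2C)n1`: 30.7%

The change from compound 1 to compound 2 is methyl in place of methoxy on an aromatic carbon and brings a number 41.1 percentage points higher from compound 1 to compound 2 (beyond the scatter). The cores of compound 1 and compound 3 differ by methoxy in place of methylsulfanyl on an aromatic carbon, which brings a number 39 percentage points higher from compound 1 to compound 3 (beyond the scatter). Between compound 2 and compound 3 the gap is a number 2.1 percentage points lower from compound 2 to compound 3 (within the scatter), so these two are not separated in this assay.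

Compound 4 `COc1cc(C)nc(NC(=S)NC(=O)c2c(-c3ccc(Cl)cc3Cl)noc2C)n1` differs from compound 3 by methyl in place of methoxy on an aromatic carbon. This is the same kind of change as that from compound 1 to compound 2, but the surroundings differ: there the place was meta to a methylsulfanyl group, here it is meta to a methoxy group. For compound 4 the step from compound 3 is estimated as a number 11.3 percentage points higher from compound 3 to compound 4 (beyond the scatter), smaller than the earlier one, because a number 2.1 percentage points lower from compound 2 to compound 3 (within the scatter) shows that the two single changes from compound 1 did not separate compound 2 from compound 3, so a further large rise from compound 3 is not supported. The value of compound 4 in this assay is estimated at 42%, with a range from 12% to 75%.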

Compound 4, percent growth inhibition at one concentration: 15.3%
Beside the measured number, compound 4's estimate is 26.7 percentage points above it; measured number inside the range.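

In this assay methyl in place of methoxy gives a number 15.4 percentage points lower from compound 3 to compound 4 (beyond the scatter) and does not carry over from the core of compound 1 to the core of compound 3, as the direction of the step reverses: the same change on two cores in this assay, a number 41.1 percentage points higher (beyond the scatter) from compound 1 to compound 2 and a number 15.4 percentage points lower (beyond the scatter) from compound 3 to compound 4, 56.5 percentage points apart, beyond the scatter of two such steps.
Methoxy in place of methylsulfanyl gives a number 17.5 percentage points lower from compound 2 to compound 4 (beyond the scatter) and reverses in the same way: the same change on two cores in this assay, a number 39 percentage points higher (beyond the scatter) from compound 1 to compound 3 and a number 17.5 percentage points lower (beyond the scatter) from compound 2 to compound 4, 56.5 percentage points apart, beyond the scatter of two such steps.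
Among the compounds shown here, the remaining step of a number 23.6 percentage points higher from compound 1 to compound 4 (beyond the scatter) is methyl in place of methylsulfanyl and has no counterpart on a second core, so the four compounds show that neither repeated change can be carried across these cores as a fixed increment, but they do not show what underlies the reversal or how either change would behave on a further core.

Still open, on these data alone, is how this place responds to groups other than methyl, methoxy and methylsulfanyl, such as an amine or a chlorine atom. Also open, as far as these compounds go, is whether both reversals persist when another part of the shared core is changed.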